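From a carbocyclic ester to a pyrrolidine ester

The source may hold more compounds than are shown below. What is called first, only, known or untested is meant among the compounds shown, and "the series" means these compounds.

Measured so far:
compound 1 `COC(=O)C1CCCCC1c1ccc(CNc2nccc(C)c2NC(=O)CC#N)cc1`: 2.2 nM
compound 2 `COC(=O)C1=C(c2ccc(CNc3nccc(C)c3NC(=O)CC#N)cc2)CCCC1`: 35 nM

Among the compounds with values here, in an assay on isolated protein for binding affinity to B1 bradykinin receptor (Homo sapiens) (a higher number here means a weaker inhibitor, a lower number a stronger inhibitor), compound 2 gives 35 nM, the higher of the two numbers seen so far; its only neighbour is compound 1, which gives 2.2 nM. Compound 3 `COC(=O)C1CCCN1c1ccc(CNc2nccc(C)c2NC(=O)CC#N)cc1` is compound 2 with 2-(methoxycarbonyl)pyrrolidin-1-yl in place of 2-(methoxycarbonyl)cyclohex-1-en-1-yl on an aromatic carbon. Within the data shown here, the single measured step, a 16-fold higher number from compound 1 to compound 2 (1.20 log units; beyond the scatter), concerns the saturation of the same six-membered ring and not the exchange of one ring for another, so it bears on compound 3 only indirectly: it shows that this position tolerates substantial change in this assay, and that the saturated ring was the stronger partner. On that slender basis the account expects compound 3 to move toward compound 1 rather than away from it, a step of a 3.5-fold lower number from compound 2 to compound 3 (0.54 log units; beyond the scatter), though with wide uncertainty. Compound 3 is estimated at 10 nM, within 2 nM to 50 nM.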

Compound 3, inhibition constant: > 5000 nM
Compound 3: a limit, no number (the forecaster's own chance of this, stated with the estimate: 5%); at least 500-fold (2.69 log units) between middle value and limit.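

In this assay compound 3 gives a limit and not a number: the limit of > 5000 nM in this assay, at which 1 of the 3 values shown sits.

Putting 2-(methoxycarbonyl)pyrrolidin-1-yl in place of 2-(methoxycarbonyl)cyclohex-1-en-1-yl gives an at least 140-fold higher number from compound 2 to compound 3 (2.15 log units; beyond the scatter), and putting it in place of 2-(methoxycarbonyl)cyclohexyl gives an at least 2200-fold higher number from compound 1 to compound 3 (3.35 log units; beyond the scatter). The earlier compounds shown here showed a change within a six-membered ring of carbon only that still left a measurable value, whereas compound 3 shows that this position does not accept every ring carrying the methoxycarbonyl group.

The compounds shown leave open whether ring size or the ring nitrogen accounts for the loss, as the two change together in compound 3. Going by these compounds, a cyclopentyl ring or a piperidine ring bearing the same methoxycarbonyl group would separate the two, and the effect of a carboxylic acid in place of the methyl ester also remains open.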